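Arylpropanoic acid amides in the rat paw edema model

A few compounds are considered here, and "the series" means these few. Any claim that something is new, unique, unknown or untested is made for them only; others in the source may bear on it.

Compound 1 `COc1cc2c(cc1OC)C(CC(=O)O)CC2` gives 20.4% in a functional assay on the whole organism (strain Wistar) for inhibition, with Rattus norvegicus as the target, read by paw edema, with stated times of 60 min and 6 h, at a dose of 100 mg/kg by the oral route; on this read-out higher numbers stand for more inhibition at the one dose given (going by the name of the read-out) and lower numbers for less inhibition.
Compound 2 `CCN(CC)C(=O)CC1CCc2cc(OC)c(OC)cc21` gives 31.5% in this assay.
Compound 3 `COc1cc2c(cc1OC)C(CC(=O)NC(C)(C)C)CC2` gives 31.5% in this assay.

Going by the values given here, compound 3 stands level with compound 2 at the digits read, the two together the highest of the three numbers; its only step beyond the scatter is the one from the acid, a number 11.1 percentage points higher from compound 1 to compound 3 (beyond the scatter). The step of no change at the digits printed from compound 2 to compound 3 (within the scatter) shows that exchanging one amide substituent for another left the read-out where it was, and the parallel step a number 11.1 percentage points higher from compound 1 to compound 2 (beyond the scatter) matched the acid-to-amide gain of compound 3 exactly.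

Compound 4 `CCCCCNC(=O)CC1CCc2cc(OC)c(OC)cc21` keeps the shared core and the amide and alters only the nitrogen substituent: pentyl in place of tert-butyl on an amide-type nitrogen. The step that bears on this is no change at the digits printed from compound 2 to compound 3 (within the scatter), within the scatter, since it also swaps one alkyl group for another on the amide nitrogen; the acid-to-amide steps do not apply, as the amide is retained. The expected change in this assay is therefore small, a number 1.5 percentage points lower from compound 3 to compound 4 (within the scatter), in no firm direction. Compound 4 is thus estimated at 30%, with a range from 18% to 42%.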

Compound 4, a percentage reported as inhibition, in the whole organism at one dose (the size of the read-out at that dose, not a potency): 35.2%
The estimate for compound 4 lay 5.2 percentage points below the measured number, and the stated range covers the measured number.
By their numbers in this assay, from the lowest: compound 1; then compounds 2, 3 and 4 (each within the scatter of the next).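

In this assay, pentyl in place of tert-butyl on the amide-type nitrogen leaves the read-out within the scatter (a number 3.7 percentage points higher from compound 3 to compound 4 (within the scatter)), so this position accepts the pentyl group as well as the tert-butyl group at the one dose given. The comparison with the diethylamino amide reads the same (a number 3.7 percentage points higher from compound 2 to compound 4 (within the scatter)), which puts all three amides of the shared core within the scatter of one another, and the choice among these three nitrogen substituents is not resolved by this read-out. The gain over the acid persists with the new group and remains beyond the scatter (a number 14.8 percentage points higher from compound 1 to compound 4 (beyond the scatter)), which extends the acid-to-amide result to a third amide, while no accompanying data bear on the reason for any of these numbers.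

Open, from the compounds shown here alone, is whether a longer chain such as octyl, a ring-bearing group such as benzylamino, or a cyclic amine such as morpholine on the carbonyl carbon would carry the read-out beyond the scatter of these three amides. Also open, going by these compounds, is how these amides would separate across several doses, since a single dose gives the size of the effect and not a potency.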